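Compound 2 and its 3,4-dihydroxyphenyl counterpart

This account rests on a few compounds, and the source may have more. Where it says the series, first, only, none or still open, it means among the compounds named here.

In a functional assay on HeLa cells (Homo sapiens) for inhibition, read by CCK-8 assay, with a stated time of 48 h (a lower number here means a stronger inhibitor, a higher number a weaker inhibitor), none of the tested compounds has yet given an exact number. Compound 1 `COc1ccc(Oc2ccc([N+](=O)[O-])cc2-c2ccsc2S(=O)(=O)N2CCN(C(=O)Nc3ccc([N+](=O)[O-])cc3)CC2)cc1OC` gives only a limit, > 50000 nM. Compound 2 `COc1ccc(Oc2ccccc2-c2ccsc2S(=O)(=O)N2CCN(C(=S)Nc3cc(C(F)(F)F)cc(C(F)(F)F)c3)CC2)cc1OC` also gives only a limit, > 50000 nM. Compound 3 `O=C(NCCNS(=O)(=O)c1cc(-c2ccccc2Oc2ccc(O)c(O)c2)cs1)Nc1cc(Cl)cc(Cl)c1`, which carries a 3,4-dihydroxyphenyl group, likewise gives only a limit, > 50000 nM. That leaves compound 2 level with the others, at the limit of > 50000 nM in this assay, at which 3 of the 3 values shown sit.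

Compound 4 `O=S(=O)(c1sccc1-c1ccccc1Oc1ccc(O)c(O)c1)N1CCN(C(=S)Nc2cc(C(F)(F)F)cc(C(F)(F)F)c2)CC1` has 3,4-dihydroxyphenyl in place of 3,4-dimethoxyphenyl on an oxygen on an aromatic ring. Going by the values given here, no measured pair shows this change, so the expectation is loose. A modest gain in strength is expected, with an estimated change an at least 2.5-fold lower number from compound 2 to compound 4 (0.39 log units; beyond the scatter). The estimate for compound 4 is 20000 nM, with an expected range of 4000 nM to 50000 nM.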

Compound 4, half-maximal inhibitory concentration: > 20000 nM
Compound 4 was reported as a limit; the forecaster's own chance of this, stated with the estimate: 45%; the middle value sits exactly at the limit.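

Going by these compounds alone, compound 2 and compound 4 both give only limits, and no step between them can be read. The compounds shown leave open whether 3,4-dihydroxyphenyl in place of 3,4-dimethoxyphenyl changes the result at all in this assay.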